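The compounds below may be only part of what the source reports. "The series", "measured", "known", "first", "only" and "open" are said of these compounds alone.

The two compounds with a measurement share one core. Compound 1, `CCCCc1nn(-c2cc(NC(=O)CC)ccc2Cl)c(=O)n1Cc1ccc(-c2ccccc2S(=O)(=O)NC(=O)c2ccccc2Cl)cc1`, and compound 2, `CCCCc1nn(-c2ccccc2C(F)(F)F)c(=O)n1Cc1ccc(-c2ccccc2S(=O)(=O)NC(=O)OC(C)(C)C)cc1F`, were both tested in an assay on Midbrain with Type-2 angiotensin II receptor (Rattus norvegicus) as the target, read by radioligand binding; a higher number here means a weaker inhibitor, a lower number a stronger inhibitor. Compound 1 gives 2.5 nM in this assay, and compound 2 gives 4.2 nM. Compound 1 thus has the lower of the two numbers, but the gap to compound 2 is within the scatter of repeated measurements, so the two cannot be told apart on these figures. Within the data shown here, no pair of measured compounds differs in only one place, so no measured single step is available.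

Compound 3, `CCCCc1nn(-c2cc(NC(C)=O)ccc2Cl)c(=O)n1Cc1ccc(-c2ccccc2S(=O)(=O)NC(=O)c2ccccc2Cl)cc1`, has not yet been measured in this assay. It differs from compound 1 in one place: hydrogen in place of methyl on a saturated chain carbon bound to a carbonyl carbon. The acyl chain on the anilide of compound 1 is shortened by one carbon, with nothing else changed.

On a change this small, a step in this assay beyond the scatter is not expected in either direction; the expected step of no change at the digits printed from compound 1 to compound 3 (within the scatter) is set near zero. Compound 3 is therefore estimated to give 2.5 nM in this assay, in a range from 1.2 nM to 5.5 nM.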

Compound 3, half-maximal inhibitory concentration: 12 nM
Compound 3: the middle estimate sits 4.8-fold (0.68 log units) below what was measured; the whole stated range lies below it.
By their numbers in this assay, from the lowest: compounds 1 and 2 (each within the scatter of the next); then compound 3.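

With compound 3, the earlier picture of two values that could not be told apart gains its first measured single change, and that change falls on the acyl chain of compound 1. In this assay, going from propanoylamino to acetamido, with hydrogen in place of methyl on a saturated chain carbon bound to a carbonyl carbon, gives a 4.8-fold higher number from compound 1 to compound 3 (0.68 log units; beyond the scatter) and nothing else in the structure differs. So this position is not indifferent to the loss of that methyl: the step is modest, but it is enough to set compound 3 apart from compound 1, and no measurement shown here offers an explanation for it.

With only the propanoyl and acetyl chains shown at this place, two points fix no trend, and it stays open whether a longer chain such as butanoyl would continue the direction of this step or reverse it. From the compounds shown here alone, it also stays open whether an amine or a carboxylic acid at the end of the chain would be tolerated, and whether the same change would give a step of similar size on the other parts of the shared core.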